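A chlorophenyl swap from compound 2 to compound 3

The source may hold more compounds than are shown below. What is called first, only, known or untested is meant among the compounds shown, and "the series" means these compounds.

Compound 1 `COc1ccc(NC(=O)Nc2cc(C)nc3ccccc23)cc1Cl`: 26000 nM
Compound 2 `Cc1cc(NC(=O)Nc2ccc(Cl)cc2)c2ccccc2n1`: > 25000 nM

In an ADME assay on HEK293 cells (Homo sapiens) for cytotoxicity, with a stated time of 72 h (a higher number here means that more compound is needed for the effect, a lower number that less compound is needed), compound 1 gives 26000 nM. Compound 2 stands at > 25000 nM, which is a limit of the assay and not a number. Compound 3 `Cc1cc(NC(=O)Nc2cccc(Cl)c2)c2ccccc2n1` has not yet been measured. It carries 3-chlorophenyl in place of 4-chlorophenyl on an amide-type nitrogen. For the measured compounds named here, no measured step shows the effect of this change, so no shift beyond the scatter is expected in this assay. The expected step is a number no higher from compound 2 to compound 3 (the limit leaves the size open). For compound 3 the estimated value is 25000 nM, with an expected range from 12000 nM to 50000 nM.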

Compound 3, half-maximal effective concentration: 21000 nM
Compound 3: the middle estimate sits 1.2-fold (0.08 log units) above what was measured, within the range that was stated.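

In this assay, compound 3 gives a number for 3-chlorophenyl on an amide-type nitrogen, with an at least 1.1-fold lower number from compound 2 to compound 3 (0.07 log units; that floor lies within the scatter). On these data alone, compound 2 holds a limit and not a number, and the full size of this step therefore stays open: the limit of > 25000 nM in this assay, at which 1 of the 3 values shown sits. Hydrogen in place of methoxy on an aromatic carbon gives a 1.2-fold lower number from compound 1 to compound 3 (0.09 log units; within the scatter), a step that stays within the scatter.

The compounds shown leave open how an amine or a carboxylic acid in place of the chlorine would read in this assay.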